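Repositioning fluorine and methoxy on the pendant aryl ring

The source may report more compounds than this note shows. Statements on the series, on what has been measured and on what is new or still open speak of the compounds shown alone.

Three compounds have numbers in an assay on isolated protein for inhibition of ribosomal protein S6 kinase alpha-2 (Homo sapiens), with a stated time of 150 min; on this read-out higher numbers stand for weaker inhibition and lower numbers for stronger inhibition. Compound 1 `COc1cccc(F)c1-c1cccc2nc(Nc3ccccc3)oc12` gives 1000 nM. Compound 2 `COc1cc(Nc2nc3cccc(-c4c(F)cccc4OC)c3o2)cc(OC)c1OC` gives 20 nM, the lowest of the three. Compound 3 `COc1cc(Nc2nc3cccc(-c4c(F)cccc4OC)c3o2)cc(OC)c1` gives 210 nM. Compound 2 stands nearest to compound 3, with the step of an 11-fold higher number from compound 2 to compound 3 (1.02 log units; beyond the scatter) for hydrogen in place of methoxy on an aromatic carbon, and furthest from compound 1, whose number lies far above that of compound 2 and which differs from it in more than one place.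

Compound 4 `COc1ccc(F)cc1-c1cccc2nc(Nc3cc(OC)c(OC)c(OC)c3)oc12` differs from compound 2 by 5-fluoro-2-methoxyphenyl in place of 2-fluoro-6-methoxyphenyl on an aromatic carbon, the same atoms joined differently: 5-fluoro-2-methoxyphenyl in place of 2-fluoro-6-methoxyphenyl on an aromatic carbon of a six-membered aromatic ring of carbon only, part of a fused system of two rings. For the measured compounds named here, no measured step touches this pendant aryl ring; the only single-point step, an 11-fold higher number from compound 2 to compound 3 (1.02 log units; beyond the scatter), lies on the aniline side. The expectation therefore rests on the structural change alone, and a moderate rise in the number, beyond the scatter but well short of compound 1, is expected. The step from compound 2 to compound 4 is expected to be a 3.0-fold higher number from compound 2 to compound 4 (0.48 log units; beyond the scatter). Compound 4 is estimated at 60 nM, within 15 nM to 300 nM.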

Compound 4, half-maximal inhibitory concentration: 40 nM
Compound 4: middle estimate off by 1.5-fold (0.18 log units), on the high side; measured number inside the range.
By their numbers in this assay, from the lowest: compounds 2 and 4 (each within the scatter of the next); then compound 3; then compound 1.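

In this assay the rearrangement on the pendant aryl ring gives a 2.0-fold higher number from compound 2 to compound 4 (0.30 log units; within the scatter) and so leaves 5-fluoro-2-methoxyphenyl and 2-fluoro-6-methoxyphenyl indistinguishable on this read-out. For the compounds shown here, the earlier single-place comparison reached only the other end of the molecule, where an 11-fold higher number from compound 2 to compound 3 (1.02 log units; beyond the scatter) lies beyond the scatter; this is the first view of the pendant ring, and swapping these two substitution patterns on this aromatic carbon does not separate the compounds. Nothing available bears on why the two arrangements read alike.

Open, as far as these compounds go, is whether the position tolerates a different kind of group, such as an amine or a carboxylic acid in place of the fluorine. Also open, from the compounds shown here alone, is whether the same rearrangement stays within the scatter when made on compound 3 or compound 1.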